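A few compounds are considered here, and "the series" means these few. Any claim that something is new, unique, unknown or untested is made for them only; others in the source may bear on it.

For the measured compounds named here, in a functional assay on A549 cells (Homo sapiens) for inhibition, read by MTT assay, with a stated time of 72 h (on this read-out higher numbers stand for weaker inhibition and lower numbers for stronger inhibition), compound 2 `Cn1ccc2c(Oc3ccc(NC(=O)c4cn(-c5ccc(Cl)cc5)c5ccccc5c4=O)cc3F)ccnc21` gives 250 nM, the lower of the two numbers measured so far, while compound 1 `Cn1ccc2c(Oc3ccc(NC(=O)c4cn(-c5ccc(F)cc5)c5ccccc5c4=O)cc3F)ccnc21` gives 1460 nM. Going by the values given here, the only measured step is a 5.8-fold lower number from compound 1 to compound 2 (0.77 log units; beyond the scatter), a modest one beyond the scatter. Compound 3 `Cn1ccc2c(Oc3ccc(NC(=O)c4cn(-c5ccc(Br)cc5)c5ccccc5c4=O)cc3F)ccnc21` differs from compound 2 by bromo in place of chloro on an aromatic carbon. Among the compounds with values here, because the one step in the same halogen series reads a 5.8-fold lower number from compound 1 to compound 2 (0.77 log units; beyond the scatter), the change to bromo is expected to continue in the same direction but more weakly. The estimated step is a 1.7-fold lower number from compound 2 to compound 3 (0.22 log units; within the scatter), close to the edge of the scatter. Compound 3 is therefore estimated at about 150 nM, with a range from 60 nM to 400 nM.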

Compound 3, half-maximal inhibitory concentration: 1390 nM
Estimate against measurement, compound 3: 9.3-fold (0.97 log units) below, outside the stated range (above it).
By their numbers in this assay, from the lowest: compound 2; then compounds 3 and 1 (each within the scatter of the next).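

In this assay this position does not follow a single trend across the halogens: the change from 4-chlorophenyl to 4-bromophenyl gives a 5.6-fold higher number from compound 2 to compound 3 (0.75 log units; beyond the scatter), which reverses the earlier gain with chloro. The bromo and fluoro groups read alike, with a 1.1-fold lower number from compound 1 to compound 3 (0.02 log units; within the scatter), so among these three halogens only chloro gives the low number. No evidence on the cause of this reversal is available. The compounds shown leave open whether the low number is particular to chloro or would also appear with a methyl group, a methoxy group or an amine at the same place.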